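The compounds below may be only part of what the source reports. "The series", "measured", "known", "first", "only" and "open" are said of these compounds alone.

Series notes. The shared core carries a cis-acrylic acid, a methoxy group and a prenyl chain, with a triazole-linked aryl group varied at the aromatic nitrogen. Compound 1 `COc1ccc(-n2cc(COc3c(/C=C\C(=O)O)ccc(OC)c3CC=C(C)C)nn2)cc1` gives "not determined" (no result reported) in a functional assay on T47D cells (Homo sapiens) for cytotoxicity, read by MTT assay, with a stated time of 24 h (on this read-out higher numbers stand for weaker inhibition and lower numbers for stronger inhibition), so no number stands for it. Compound 2 `COc1ccc(/C=C\C(=O)O)c(OCc2cn(-c3cccc([N+](=O)[O-])c3)nn2)c1CC=C(C)C` gives 15400 nM in this assay. Compound 3 `COc1ccc(/C=C\C(=O)O)c(OCc2cn(-c3cccc(C#N)c3)nn2)c1CC=C(C)C` gives 19200 nM in this assay, the higher of the two numbers, with compound 2 nearest at a 1.2-fold higher number from compound 2 to compound 3 (0.10 log units; within the scatter).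

Compound 4 `COc1ccc(/C=C\C(=O)O)c(OCc2cn(-c3nc4ccccc4s3)nn2)c1CC=C(C)C` differs from compound 3 in one place: 1,3-benzothiazol-2-yl in place of 3-cyanophenyl on an aromatic nitrogen. Among the measured compounds shown here, the only measured step, from compound 2 to compound 3, also sits on the aromatic nitrogen of the triazole but swaps one substituent of a phenyl ring for another, and it lay within the scatter. It tells nothing about exchanging 3-cyanophenyl for 1,3-benzothiazol-2-yl, so no step beyond the scatter is expected in this assay for compound 4, with wide uncertainty. The estimate for compound 4 is 17000 nM, range 6000 nM to 48000 nM, which means an expected step of a 1.1-fold lower number from compound 3 to compound 4 (0.05 log units; within the scatter).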

Compound 4, half-maximal inhibitory concentration: 17200 nM
Compound 4: the middle estimate sits 1.0-fold (0.01 log units) below what was measured, within the range that was stated.
By their numbers in this assay, from the lowest: compounds 2, 4 and 3 (each within the scatter of the next).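

In this assay, replacing the whole aryl group on the aromatic nitrogen, and not only a substituent of the phenyl ring, gives a 1.1-fold lower number from compound 3 to compound 4 (0.05 log units; within the scatter). Measured against the nitro-bearing analogue, the same kind of exchange gives a 1.1-fold higher number from compound 2 to compound 4 (0.05 log units; within the scatter). At this position of the five-membered aromatic ring with 3 nitrogen, 1,3-benzothiazol-2-yl, with its added five-membered aromatic ring holding 2 hetero atoms, therefore leaves the number within the scatter of both 3-cyanophenyl and 3-nitrophenyl; no measured evidence accompanies this result to explain it.

Steps to compound 1 cannot be read, as it has no number. As far as these compounds go, whether a piperidine or a benzyl group on this nitrogen, or a methyl ester in place of the carboxylic acid, would give a step beyond the scatter remains open.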